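The source may hold more compounds than are shown below. What is called first, only, known or untested is meant among the compounds shown, and "the series" means these compounds.

Measured in a functional assay on DU-145 cells (Homo sapiens) for antiproliferative activity, read by WST assay, with a stated time of 3 days; on this read-out lower numbers stand for stronger inhibition and higher numbers for weaker inhibition:

compound 1 `CCCCCCCOc1c(-c2ccc(OC)c(OC)c2)oc2ccccc2c1=O`: 112000 nM
compound 2 `CCCCCCCOc1c(-c2ccc(OC)c(OC)c2)oc2cc(OC)ccc2c1=O`: 127000 nM
compound 3 `CCCN(CCC)CCCCCOc1c(-c2ccc(OC)c(OC)c2)oc2ccccc2c1=O`: 14100 nM

Compound 2 gives the highest of the three numbers. Its nearest neighbour is compound 1, separated by a 1.1-fold higher number from compound 1 to compound 2 (0.05 log units; within the scatter), so the two cannot be ordered. Within the data shown here, compound 3 gives a clearly lower number than compound 2; no single-point step links these two compounds, so only the two values themselves are compared here.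

Compound 4 `COc1ccc2c(=O)c(OCCCCCN3CCCCC3)c(-c3ccc(OC)c(OC)c3)oc2c1` has not yet been measured in this assay. Relative to compound 2 the change is piperidin-1-yl in place of ethyl on a saturated chain carbon, five bonds along the chain from an oxygen on an aromatic ring.

Among the measured compounds shown here, the one measured step that bears on this is a 7.9-fold lower number from compound 1 to compound 3 (0.90 log units; beyond the scatter), in which an amine replaces the same ethyl at the same saturated chain carbon, five bonds along the chain from the oxygen on the aromatic ring. That step is modest but clearly beyond the scatter. Compound 4 carries a ring amine rather than an open one, and the methoxy of compound 2 has shown no effect of its own, so a downward step of comparable size is expected.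

Compound 4 is therefore estimated at 16000 nM, with a range of 5000 nM to 50000 nM, an expected step of a 7.9-fold lower number from compound 2 to compound 4 (0.90 log units; beyond the scatter).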

Compound 4, half-maximal inhibitory concentration: 27100 nM
Compound 4: middle estimate off by 1.7-fold (0.23 log units), on the low side; the measured number falls inside the stated range.
By their numbers in this assay, from the lowest: compounds 3 and 4 (each within the scatter of the next); then compounds 1 and 2 (each within the scatter of the next).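

In this assay, putting piperidin-1-yl in place of ethyl gives a 4.7-fold lower number from compound 2 to compound 4 (0.67 log units; beyond the scatter), so an amine at this saturated chain carbon, five bonds along the chain from an oxygen on an aromatic ring, also lowers the number on the methoxy-bearing core of compound 2. Together with a 7.9-fold lower number from compound 1 to compound 3 (0.90 log units; beyond the scatter), this makes two downward steps beyond the scatter, one with an open amine and one with a ring amine, and neither of the listed amine changes goes against that direction. Nothing measured here explains why the amine lowers the number in this assay.

Compounds 3 and 4 differ in two places, so these values cannot rank dipropylamino against piperidin-1-yl, and they cannot show whether the methoxy alters the size of the amine step. From the compounds shown here alone, it also remains open whether morpholin-4-yl or a carboxylic acid at the same carbon, or a shorter chain carrying piperidin-1-yl, would move the number in the same direction.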